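Methoxy on the benzoyl group of compound 2

This account rests on a few compounds, and the source may have more. Where it says the series, first, only, none or still open, it means among the compounds named here.

Compound 1 `CCSc1nnc(-c2cc(OC)c(OC)c(OC)c2)n1-c1ccc(OC)cc1` gives > 60000 nM in a functional assay on HCT-116 cells (Homo sapiens) for inhibition, read by MTT assay, with a stated time of 48 h (on this read-out lower numbers stand for stronger inhibition and higher numbers for weaker inhibition), which is a limit of the assay. Compound 2 `COc1ccc(-n2c(SCC(=O)c3ccccc3)nnc2-c2cc(OC)c(OC)c(OC)c2)cc1` gives > 60000 nM in this assay, again a limit. Going by the values given here, compound 2 therefore has no numerical value, and the series so far shows only (the limit of > 60000 nM in this assay, at which 2 of the 2 values shown sit). Among the compounds with values here, the single measured change is a step that the two limits leave unreadable from compound 1 to compound 2, so it offers no size to carry forward. Compound 3 `COc1ccc(C(=O)CSc2nnc(-c3cc(OC)c(OC)c(OC)c3)n2-c2ccc(OC)cc2)cc1` differs from compound 2 by methoxy in place of hydrogen on an aromatic carbon, para to a large group, turning benzoyl into (4-methoxyphenyl)carbonyl. Within the data shown here, no measured step covers this change. In this assay, no step beyond the scatter is expected, and a further limit is the likeliest result. The expected change is a number no higher from compound 2 to compound 3 (the limit leaves the size open). For compound 3 the estimate is 60000 nM, with an expected range of 20000 nM to 120000 nM.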

Compound 3, half-maximal inhibitory concentration: > 60000 nM
Compound 3 gave a limit, no number; the forecaster's own chance of this, stated with the estimate: 75%; the middle value sits exactly at the limit.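

No step can be read among compound 1, compound 2 and compound 3, since all three give only a limit and no number: the limit of > 60000 nM in this assay, at which 3 of the 3 values shown sit.

The compounds shown leave open how large these changes are, and whether any compound on the shared core gives a number in this assay at all.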